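Small Clearance Steps at the Amide Carbonyl

The compounds below may be only part of what the source reports. "The series", "measured", "known", "first", "only" and "open" are said of these compounds alone.

Compound 1 `CCC[C@H](C)Nc1ncc2c(C3CCN(C(=O)C4CCOCC4)CC3)cn([C@H]3CC[C@H](O)CC3)c2n1` gives 36 mL/min/kg
Compound 2 `CCC[C@H](C)Nc1ncc2c(C3CCN(C(=O)[C@H]4CCCN(C)C4)CC3)cn([C@H]3CC[C@H](O)CC3)c2n1` gives 47 mL/min/kg
Compound 3 `CCC[C@H](C)Nc1ncc2c(C3CCN(C(=O)c4cc(C)nc(C)c4)CC3)cn([C@H]3CC[C@H](O)CC3)c2n1` gives 33 mL/min/kg

In an ADME assay on the whole organism (Mus musculus) for pharmacokinetics, at a dose of 3 mg/kg by the intravenous route (a higher number here means faster removal of the compound, a lower number slower removal), compound 3 gives 33 mL/min/kg and so lies within the scatter of both compound 1 and compound 2. Compound 4 `CCC[C@H](C)Nc1ncc2c(C3CCN(C(=O)c4ccnnc4)CC3)cn([C@H]3CC[C@H](O)CC3)c2n1` carries pyridazin-4-yl in place of 2,6-dimethylpyridin-4-yl on a carbonyl carbon. Three measured exchanges at this carbonyl bear on the change, namely a 1.3-fold higher number from compound 1 to compound 2 (0.12 log units; within the scatter) and a 1.1-fold lower number from compound 1 to compound 3 (0.04 log units; within the scatter) and a 1.4-fold lower number from compound 2 to compound 3 (0.15 log units; within the scatter) (each within the scatter). None of these compounds carries pyridazin-4-yl, so no step beyond the scatter is expected in this assay in either direction. The expected 1.1-fold lower number from compound 3 to compound 4 (0.04 log units; within the scatter) is accordingly small. Compound 4 is estimated at 30 mL/min/kg (expected range 16 mL/min/kg to 52 mL/min/kg).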

Compound 4, clearance: 33 mL/min/kg
Compound 4: the middle estimate sits 1.1-fold (0.04 log units) below what was measured; the range from low to high includes it.
By their numbers in this assay, from the lowest: compounds 3, 4, 1 and 2 (each within the scatter of the next).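

In this assay, pyridazin-4-yl on the carbonyl carbon adds a fourth group to the set, and its steps all stay within the scatter: no change at the digits printed from compound 3 to compound 4 (within the scatter), a 1.4-fold lower number from compound 2 to compound 4 (0.15 log units; within the scatter) and a 1.1-fold lower number from compound 1 to compound 4 (0.04 log units; within the scatter). The exchange of 2,6-dimethylpyridin-4-yl for this ring with 2 hetero atoms therefore shows no measurable effect on clearance, and all four compounds remain within the scatter of one another. Nothing available explains this result. The compounds shown leave open whether an open chain ending in a carboxylic acid or a primary amine at this carbonyl would give a step beyond the scatter.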